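Adding an amino group to the phenyl of compound 3

The compounds below may be only part of what the source reports. "The series", "measured", "known", "first", "only" and "open" are said of these compounds alone.

In a functional assay on the whole organism with Mus musculus as the target (a lower number here means that less compound is needed, a higher number that more compound is needed for the effect), compound 3 `COc1cc2c(cc1OC)C(c1ccccc1)=NNC(=O)C2` gives 31.8 umol/kg. That value lies within the scatter of compound 2 `COc1cc2c(cc1OC)C(c1ccc(Br)cc1)=NN=C(S)C2` at 33.3 umol/kg. Compound 1 `COc1cc2c(cc1OC)C(c1ccc([N+](=O)[O-])cc1)=NN=C(S)C2` gives 69.8 umol/kg, a higher number than that of compound 3 and beyond the scatter.

Compound 4 `COc1cc2c(cc1OC)C(c1cccc(N)c1)=NNC(=O)C2` differs from compound 3 by amino in place of hydrogen on an aromatic carbon, taking phenyl to 3-aminophenyl.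

Among the measured compounds shown here, only one measured step bears on this change, and only indirectly. It is a 2.1-fold lower number from compound 1 to compound 2 (0.32 log units; beyond the scatter), a modest step for bromo in place of nitro on an aromatic carbon. That pair has a different core from compound 3, and neither of its compounds carries an amino group. For the measured compounds named here, no measured step replaces a hydrogen on this phenyl, so the direction stays open, and only a small change is expected. The expected step is a 1.1-fold lower number from compound 3 to compound 4 (0.03 log units; within the scatter), with nothing beyond the scatter anticipated. For compound 4 the estimated value is 30 umol/kg, with an expected range of 12 umol/kg to 75 umol/kg.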

Compound 4, dose for half-maximal effect: 18.3 umol/kg
Estimate against measurement, compound 4: 1.6-fold (0.21 log units) above, within the range that was stated.
By their numbers in this assay, from the lowest: compounds 4, 3 and 2 (each within the scatter of the next); then compound 1.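

The amino group on this phenyl gives a step that can be read directly, a 1.7-fold lower number from compound 3 to compound 4 (0.24 log units; within the scatter), in this assay. Phenyl to 3-aminophenyl is therefore the only measured replacement of a hydrogen on this ring, and the group is accepted on the core of compound 3 without a change beyond the scatter; the direction of the step cannot be taken as established. Nothing available explains this outcome or ties it to any property of the amino group.

Still open, as far as these compounds go, is whether a hydroxyl, a methoxy or an acetamido group at this carbon would move the number beyond the scatter. From the compounds shown here alone, it is also open whether the amino group would behave alike on the core of compound 1.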